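The source may hold more compounds than are shown below. What is called first, only, known or untested is meant among the compounds shown, and "the series" means these compounds.

Compound 1 `O=C(Nc1cccc(-n2cc(-c3ccncc3)c(-c3ccc(Cl)c(O)c3)n2)c1)Nc1cccc(C(F)(F)F)c1` carries a urea linking the shared core to a 3-(trifluoromethyl)phenyl group. In a functional assay on SF-268 cells (Homo sapiens) for inhibition, read by sulforhodamine B assay, with a stated time of 48 h (on this read-out higher numbers stand for weaker inhibition of growth and lower numbers for stronger inhibition of growth), compound 1 gives 1950 nM, and its two neighbours sit within the scatter of it: compound 2 `O=C(Nc1cccc(-n2cc(-c3ccncc3)c(-c3ccc(Cl)c(O)c3)n2)c1)Nc1ccc(Cl)c(Cl)c1` gives 1490 nM, a change of a 1.3-fold lower number from compound 1 to compound 2 (0.12 log units; within the scatter), and compound 3 `COc1cc(-c2nn(-c3cccc(NC(=O)Nc4cccc(C(F)(F)F)c4)c3)cc2-c2ccncc2)ccc1Cl` gives 1360 nM, a change of a 1.4-fold lower number from compound 1 to compound 3 (0.16 log units; within the scatter). Compound 4 `O=C(Nc1cccc(-n2cc(-c3ccncc3)c(-c3ccc(Cl)c(O)c3)n2)c1)Nc1cc(C(F)(F)F)cc(C(F)(F)F)c1` differs from compound 1 by trifluoromethyl in place of hydrogen on an aromatic carbon. Going by the values given here, the nearest precedent is the step from compound 1 to compound 2, where a different pattern on the same phenyl ring moved the number only within the scatter, so no step beyond the scatter is expected here either. Compound 4 is therefore estimated at 1500 nM, between 600 nM and 4000 nM, a step of a 1.3-fold lower number from compound 1 to compound 4 (0.11 log units; within the scatter).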

Compound 4, concentration for 50% growth inhibition: 846 nM
The estimate for compound 4 lay 1.8-fold (0.25 log units) above the measured number; the range from low to high includes it.
By their numbers in this assay, from the lowest: compounds 4, 3, 2 and 1 (each within the scatter of the next, the first and the last beyond it).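

Placing a second trifluoromethyl group on an aromatic carbon, meta to the first trifluoromethyl group, gives the only step in this assay shown here that goes beyond the scatter: a 2.3-fold lower number from compound 1 to compound 4 (0.36 log units; beyond the scatter). The two earlier steps from compound 1 stayed within the scatter, so this added group shows that a change on this ring can move the number, though only modestly. Nothing available here explains the shift. Still open, going by these compounds, is whether an amine or a carboxylic acid at this same position would lower the number, raise it or leave it unchanged.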